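This account rests on a few compounds, and the source may have more. Where it says the series, first, only, none or still open, it means among the compounds named here.

Compound 1 `O=C(CCCCCc1ccccc1)OCC1COCCOCCOCCOCCOCCO1` is a crown-ether ester whose carbonyl carbon carries a 5-phenylpentyl chain. In a functional assay on HBL-100 cells (Homo sapiens) for inhibition, read by sulforhodamine B assay, with a stated time of 48 h (on this read-out lower numbers stand for stronger inhibition of growth and higher numbers for weaker inhibition of growth), compound 1 gives 64000 nM, the highest number among the three measured compounds. Its nearest neighbour is compound 3 `CC(C)=CC1C(C(=O)OCC2COCCOCCOCCOCCOCCO2)C1(C)C`, which gives 40000 nM; the step of a 1.6-fold lower number from compound 1 to compound 3 (0.20 log units; within the scatter) is within the scatter. The furthest is compound 2 `O=C(OCC1COCCOCCOCCOCCOCCO1)c1cccc(-c2ccc(Br)cc2)c1`, which gives 6400 nM, a lower number than that of compound 1 in this assay, and here an aromatic ring sits directly on the carbonyl carbon.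

Compound 4 `O=C(/C=C/c1ccccc1)OCC1COCCOCCOCCOCCOCCO1` differs from compound 1 in one place: 2-phenylethenyl in place of 5-phenylpentyl on a carbonyl carbon. Among the measured compounds shown here, the only measured step that changes the group on the carbonyl carbon, from compound 1 to compound 3, stayed within the scatter; the comparison of compound 1 with compound 2 suggests that a shorter link from the carbonyl to the phenyl ring may go with a lower number, though no step between these two is established. Compound 4 is therefore expected to show a modest improvement, a 2.1-fold lower number from compound 1 to compound 4 (0.33 log units; beyond the scatter), with the estimate for compound 4 in this assay at 30000 nM and a range from 10000 nM to 90000 nM.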

Compound 4, concentration for 50% growth inhibition: 57000 nM
Beside the measured number, compound 4's estimate is 1.9-fold (0.28 log units) below it; measured number inside the range.
By their numbers in this assay, from the lowest: compound 2; then compounds 3, 4 and 1 (each within the scatter of the next).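

In this assay, 2-phenylethenyl in place of 5-phenylpentyl on a carbonyl carbon gives a 1.1-fold lower number from compound 1 to compound 4 (0.05 log units; within the scatter) and 2-phenylethenyl in place of 2,2-dimethyl-3-(2-methylprop-1-en-1-yl)cyclopropyl gives a 1.4-fold higher number from compound 3 to compound 4 (0.15 log units; within the scatter) in the same place. Compounds 1, 3 and 4 therefore all lie within the scatter of one another, so exchanging these three groups, including the exchange of the 11-carbon 5-phenylpentyl group for the 8-carbon 2-phenylethenyl group with its double bond outside the aromatic ring, leaves no readable difference at this position. Nothing available accounts for this result.

From the compounds shown here alone, what 2-phenylethyl, or a phenyl ring carrying an amine or a carboxylic acid, would give on this carbonyl carbon remains open. Also open, going by these compounds, is how much of these numbers belongs to the shared core rather than to the group on the carbonyl carbon.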